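Aryl ether variation at the cyclohexyl position of the macrolide

The compounds below may be only part of what the source reports. "The series", "measured", "known", "first", "only" and "open" are said of these compounds alone.

Compound 1 `CC[C@@H]1/C=C(\C)C[C@H](C)C[C@H](OC)[C@H]2O[C@@](O)(C(=O)C(=O)N3CCCC[C@H]3C(=O)O[C@H](/C(C)=C/[C@@H]3CC[C@@H](Oc4ccc(O)cc4)[C@H](OC)C3)[C@H](C)[C@@H](O)CC1=O)[C@H](C)C[C@@H]2OC` is the reference point of this pair: in a functional assay on cells for inhibition, with Murine T-cell line (Mus musculus) as the target (on this read-out lower numbers stand for stronger inhibition and higher numbers for weaker inhibition), compound 1 gives 0.8 nM. Compound 2 `CC[C@@H]1/C=C(\C)C[C@H](C)C[C@H](OC)[C@H]2O[C@@](O)(C(=O)C(=O)N3CCCC[C@H]3C(=O)O[C@H](/C(C)=C/[C@@H]3CC[C@@H](Oc4ccc(C)cc4)[C@H](OC)C3)[C@H](C)[C@@H](O)CC1=O)[C@H](C)C[C@@H]2OC` carries methyl in place of hydroxy on an aromatic carbon, and in this assay compound 2 gives 2.7 nM. Among the compounds with values here, that single measured step, a 3.4-fold higher number from compound 1 to compound 2 (0.53 log units; beyond the scatter), leaves compound 2 standing as the higher of the two numbers so far, with compound 1 as its only neighbour.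

Compound 3 `CC[C@@H]1/C=C(\C)C[C@H](C)C[C@H](OC)[C@H]2O[C@@](O)(C(=O)C(=O)N3CCCC[C@H]3C(=O)O[C@H](/C(C)=C/[C@@H]3CC[C@@H](Oc4cccc(OC)c4)[C@H](OC)C3)[C@H](C)[C@@H](O)CC1=O)[C@H](C)C[C@@H]2OC` changes the aryl group again: 3-methoxyphenyl in place of 4-methylphenyl on an oxygen on a saturated carbon. Within the data shown here, no measured step matches this exchange directly. Among the measured compounds shown here, the one step that bears on it, the exchange from compound 1 to compound 2, was modest, so a comparable or smaller shift is expected here, most plausibly toward a lower number than compound 2 but not reaching compound 1. The expected step is a 1.4-fold lower number from compound 2 to compound 3 (0.13 log units; within the scatter). For compound 3 in this assay the estimate is 2 nM, with a range from 0.7 nM to 6 nM.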

Compound 3, half-maximal inhibitory concentration: 3.4 nM
For compound 3 the middle estimate is 1.7-fold (0.23 log units) below the measured one; the measured number falls inside the stated range.
By their numbers in this assay, from the lowest: compound 1; then compounds 2 and 3 (each within the scatter of the next).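

In this assay, the exchange of 4-methylphenyl for 3-methoxyphenyl on an oxygen on a saturated carbon gives a 1.3-fold higher number from compound 2 to compound 3 (0.10 log units; within the scatter), so these two aryl groups cannot be told apart on this read-out. The exchange of 4-hydroxyphenyl for 3-methoxyphenyl gives a 4.3-fold higher number from compound 1 to compound 3 (0.63 log units; beyond the scatter), which places compound 3 with compound 2 and leaves compound 1 as the only one of the three apart from the others. No evidence is available that accounts for this result.

The compounds shown leave open whether the separation of compound 1 depends on the hydroxy group itself, since 3-hydroxyphenyl and 4-methoxyphenyl do not appear among them. Also open, going by these compounds, is how an aminophenyl group, a carboxylic acid on the aryl ring or a simple alkyl chain on the same oxygen would read in this assay on this core.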